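This account rests on a few compounds, and the source may have more. Where it says the series, first, only, none or still open, it means among the compounds named here.

Working notes on the side chain of the shared core, read in a functional assay on HCT-15 cells (Homo sapiens) for antiproliferative activity, read by sulforhodamine B assay; on this read-out higher numbers stand for weaker inhibition of growth and lower numbers for stronger inhibition of growth. Compound 1 (`O=C(/C=C/c1ccc(O)cc1)c1c(O)cccc1OCCC1CCCCC1`) reaches only a limit of the assay, > 30000 nM. Compound 2 (`O=C(/C=C/c1ccc(O)cc1)c1c(O)cccc1OCC1CCCCC1`) also reaches only a limit, > 30000 nM. That leaves a step that the two limits leave unreadable from compound 1 to compound 2, and both compounds belong to the limit of > 30000 nM in this assay, at which 2 of the 3 values shown sit. Among the compounds with values here, compound 3 (`CCC(CC)COc1cccc(O)c1C(=O)/C=C/c1ccc(O)cc1`) gives 3420 nM, the only actual number so far in this assay.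

The next change leads to compound 4 (`CC(C)COc1cccc(O)c1C(=O)/C=C/c1ccc(O)cc1`): isopropyl in place of pentan-3-yl on a saturated chain carbon bound to an oxygen on an aromatic ring. In words, isopropyl stands in place of pentan-3-yl on a saturated chain carbon bound to an oxygen on an aromatic ring.

Within the data shown here, two measured steps bear on this only indirectly: an at least 8.7-fold lower number from compound 1 to compound 3 (0.94 log units; beyond the scatter) and an at least 8.7-fold lower number from compound 2 to compound 3 (0.94 log units; beyond the scatter). Each replaces a cyclohexyl-bearing group with pentan-3-yl, and each size rests on a limit. Among the measured compounds shown here, no measured step exchanges one open-chain group for another. A step beyond the scatter is therefore not expected, with a slight lean towards a higher number. The expected step is a 1.5-fold higher number from compound 3 to compound 4 (0.16 log units; within the scatter). For compound 4 the estimated value is 5000 nM, with an expected range of 1700 nM to 20000 nM.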

Compound 4, concentration for 50% growth inhibition: 2600 nM
Estimate against measurement, compound 4: 1.9-fold (0.28 log units) above; measured number inside the range.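

In this assay, the exchange of pentan-3-yl for isopropyl on a saturated chain carbon bound to an oxygen on an aromatic ring stays within the scatter: a 1.3-fold lower number from compound 3 to compound 4 (0.12 log units; within the scatter). Within the data shown here, two open-chain groups now read alike at this position, which the single number for compound 3 could not show. Set against the cyclohexyl-bearing groups, isopropyl gives an at least 11-fold lower number from compound 2 to compound 4 (1.06 log units; beyond the scatter) and an at least 11-fold lower number from compound 1 to compound 4 (1.06 log units; beyond the scatter), with each size resting on a limit of the assay: the limit of > 30000 nM in this assay, at which 2 of the 4 values shown sit.

From the compounds shown here alone, whether a smaller group such as methyl or a longer chain such as hexyl would hold this level remains open, as does whether a smaller ring such as cyclopropyl would share the limit of compound 1 and compound 2. Going by these compounds, the step between those two compounds cannot be read, and the full size of their gap to compound 4 is unknown.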